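Notes on Compound 1 and an Untested Analogue

The source may report more compounds than this note shows. Statements on the series, on what has been measured and on what is new or still open speak of the compounds shown alone.

Measured so far:
compound 1 `CCOC(=O)C1=C(Nc2ccccc2)S/C(=C\c2cccc(C(=O)O)c2)C1=O` gives 16200 nM
compound 2 `CCOC(=O)C1=C(Nc2ccc([N+](=O)[O-])cc2)S/C(=C\c2ccc[nH]2)C1=O` gives > 100000 nM (a limit, not a number)

Among the compounds with values here, in a functional assay on K562 cells (Homo sapiens) for inhibition, read by MTT assay, with a stated time of 72 h (on this read-out lower numbers stand for stronger inhibition and higher numbers for weaker inhibition), compound 1 gives 16200 nM, the only numeric value in hand and therefore the sole reference point for the series. The other result is the limit of > 100000 nM in this assay, at which 1 of the 2 values shown sits; this belongs to compound 2, which gives > 100000 nM, a limit of the assay rather than a number.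

Compound 3 `CCOC(=O)C1=C(Nc2ccccc2)S/C(=C\c2cc3cccnc3[nH]2)C1=O` differs from compound 1 by a group of 9 heavy atoms (7 carbon, 2 nitrogen; one five-membered aromatic ring with 1 hetero atom, one six-membered aromatic ring with 1 hetero atom) in place of a group of 9 heavy atoms (7 carbon, 2 oxygen; one six-membered aromatic ring of carbon only), on a double-bonded chain carbon bound to a double-bonded ring carbon. Within the data shown here, no pair of measured compounds differing in one place is available, so nothing in the data sets the size of this step; the expectation rests on compound 1 alone. The step from compound 1 to compound 3 is estimated as a 2.0-fold lower number from compound 1 to compound 3 (0.31 log units; beyond the scatter), a modest gain that may not clear the scatter. Compound 3 is accordingly expected to give 8000 nM in this assay, within a range from 2000 nM to 40000 nM.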

Compound 3, half-maximal inhibitory concentration: > 100000 nM
Compound 3: only a limit was reported; the forecaster's own chance of this, stated with the estimate: 15%; middle value at least 12-fold (1.09 log units) from the limit.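

Compound 3 gives > 100000 nM in this assay, which is a limit and not a number. At the double-bonded chain carbon bound to a double-bonded ring carbon, this first single-place change gives an at least 6.1-fold higher number from compound 1 to compound 3 (0.79 log units; beyond the scatter), so the series is sensitive to the group at this place, even though the two groups match in heavy atoms, hydrogen-bond donors and hydrogen-bond acceptors as counted. How large the step really is cannot be read, and limits dominate the set: the limit of > 100000 nM in this assay, at which 2 of the 3 values shown sit.

The compounds shown leave open whether the 3-carboxyphenyl group as a whole or its carboxylic acid alone sets the value of compound 1. A plain phenyl or an aminophenyl group at this place would separate the two, and compound 2 cannot help, as it differs from compound 1 in more than one place.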